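Disulfide half-life at neutral pH: from butyl to aminoethyl

The source may report more compounds than this note shows. Statements on the series, on what has been measured and on what is new or still open speak of the compounds shown alone.

Two disulfide nucleosides have been examined in a physicochemical assay for pharmacokinetics, at pH 7.2; a lower number here means that the compound disappears faster, a higher number that the compound lasts longer. Compound 1 `CSS[C@H]1C[C@H](n2ccc(N)nc2=O)O[C@@H]1CO` carries a methyl disulfide. In this assay compound 1 gives < 0.0834 h, which is a limit of the assay rather than a number. Compound 2 `CCCCSS[C@H]1C[C@H](n2cc(C)c(=O)[nH]c2=O)O[C@@H]1CO` carries a butyl disulfide on a thymine nucleoside. In this assay compound 2 gives < 0.0834 h, again a limit and not a number. Thus compound 2 stands at the same limit as the one other value shown, the two together forming (the limit of < 0.0834 h in this assay, at which 2 of the 2 values shown sit). Compound 3 `Cc1cn([C@H]2C[C@H](SSCCN)[C@@H](CO)O2)c(=O)[nH]c1=O` differs from compound 2 by amino in place of ethyl on a saturated chain carbon, two bonds along the chain from a sulfur. Among the measured compounds shown here, no measured step connects compounds of this kind, so no size or direction can be read from the data. With both known values sitting at the limit, compound 3 is expected to fall at the limit as well, with a half-life estimated at 0.05 h between 0.015 h and 0.17 h, and the expected step that the limit leaves unreadable from compound 2 to compound 3 lies within the scatter.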

Compound 3, half-life: < 0.0834 h
Compound 3: only a limit was reported; the forecaster's own chance of this, stated with the estimate: 70%; the middle value lies beyond the limit too.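

In this assay compound 3 gives < 0.0834 h, which is a limit and not a number. Compound 2 also stands at a limit, so no step between compound 2 and compound 3 can be read: the limit of < 0.0834 h in this assay, at which 3 of the 3 values shown sit.

The compounds shown leave open how long any of these disulfides actually lasts in this assay, and whether amino in place of ethyl makes any difference.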